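A few compounds are considered here, and "the series" means these few. Any claim that something is new, unique, unknown or untested is made for them only; others in the source may bear on it.

Measured so far in a functional assay on CHO cells for agonist activity at Free fatty acid receptor 1 (Homo sapiens), read by calcium flux; on this read-out higher numbers stand for an effect only at larger amounts of compound and lower numbers for an effect already at smaller amounts:
compound 1 `O=C(O)CCc1nnc(C(=O)Nc2cccc(-c3cccc(Cl)c3)c2)s1`, 1690 nM
compound 2 `O=C(O)CCc1nnc(C(=O)Nc2cccc(-c3ccc(F)cc3)c2)s1`, 1280 nM
compound 3 `O=C(O)CCc1ccc(OCc2nnc(C(=O)Nc3ccc(F)cc3)s2)cc1`, 6640 nM

Compound 3 gives the highest number of the three; compound 1 and compound 2 both sit below it by gaps beyond the scatter. Compound 3 differs from compound 1 and from compound 2 in more than one place, so these gaps cannot be tied to any single change.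

Compound 4 `Cc1ccc(NC(=O)c2nnc(COc3ccc(CCC(=O)O)cc3)s2)cc1` is not yet measured. It differs from compound 3 in one place: methyl in place of fluoro on an aromatic carbon. Going by the values given here, the only measured single-change step is a 1.3-fold lower number from compound 1 to compound 2 (0.12 log units; within the scatter), which swaps one halogen for another on a different ring and stays within the scatter. Among the compounds with values here, no measured step exchanges fluoro for methyl, and none touches the ring on which this change sits. Within the data shown here, the one precedent available suggests that a small change on an outer aromatic ring moves the number little. Compound 4 is therefore expected to show a step of a 1.1-fold lower number from compound 3 to compound 4 (0.04 log units; within the scatter) that does not go beyond the scatter. The estimate for compound 4 in this assay is 6000 nM, with a range from 2000 nM to 18000 nM.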

Compound 4, half-maximal effective concentration: 4300 nM
For compound 4 the middle estimate is 1.4-fold (0.14 log units) above the measured one; the measured number falls inside the stated range.
By their numbers in this assay, from the lowest: compounds 2 and 1 (each within the scatter of the next); then compounds 4 and 3 (each within the scatter of the next).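

In this assay, methyl in place of fluoro on the six-membered aromatic ring, para to a large group, gives a 1.5-fold lower number from compound 3 to compound 4 (0.19 log units; within the scatter), so at this position the two groups are not told apart by this read-out. Going by these compounds alone, this is the first single-place step at this position and the first that replaces a halogen with a carbon group; the only earlier step exchanged 3-chlorophenyl for 4-fluorophenyl on another core. No measurement at hand bears on why the two groups read alike.

Going by these compounds, whether an amine, a methoxy group or a trifluoromethyl group at this position would also stay within the scatter remains open. Also open, on these data alone, is whether the same exchange reads alike on the 4-fluorophenyl group of compound 2.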